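Notes on the step from compound 3 to compound 4

This account rests on a few compounds, and the source may have more. Where it says the series, first, only, none or still open, it means among the compounds named here.

Measured in a functional assay on C6 cells (Rattus norvegicus) for cytotoxicity, read by MTT assay, with a stated time of 24 h, tested at 100 ug/mL; on this read-out higher numbers stand for a weaker effect at the one concentration tested and lower numbers for a stronger effect:
- compound 1 `Cc1nnc(SCC(=O)N/N=c2/scc(-c3ccc(F)cc3)n2-c2ccccc2)s1` gives 34.9%
- compound 2 `O=C(CSc1nnnn1-c1ccccc1)N/N=c1/scc(-c2ccc(F)cc2)n1-c1ccccc1` gives 35.8%
- compound 3 `O=C(CSc1ncccn1)N/N=c1/scc(-c2ccc(Cl)cc2)n1-c1ccccc1` gives 45.5%

Compound 3 stands highest of the three numbers in this assay; its gap to compound 2 is within the scatter, its gap to compound 1 beyond it. Among the compounds with values here, the one measured step, a number 0.9 percentage points higher from compound 1 to compound 2 (within the scatter), concerns the group on the sulfur and is within the scatter.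

Compound 4 `O=C(CSc1ncccn1)N/N=c1/scc(-c2ccc(F)cc2)n1-c1ccccc1` is not yet measured. Within the data shown here, it differs from compound 3 by fluoro in place of chloro on an aromatic carbon, a change no measured step covers. What the numbers do show is that the two fluoro compounds, compound 1 and compound 2, sit lower than the chloro compound 3 in this assay, though they also carry other groups on the sulfur. On that basis the step of a number 5.5 percentage points lower from compound 3 to compound 4 (within the scatter) is expected to run downward but not clearly beyond the scatter. Compound 4 is therefore estimated at 40% in this assay, with a range from 30% to 50%.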

Compound 4, a percentage reported as activity, at one concentration (the size of the read-out at that concentration, not a potency): 53.4%
Compound 4: the middle estimate sits 13.4 percentage points below what was measured; measured number outside the range, above it.
By their numbers in this assay, from the lowest: compounds 1, 2, 3 and 4 (each within the scatter of the next, the first and the last beyond it).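

At the position para to a large group, the step of a number 7.9 percentage points higher from compound 3 to compound 4 (within the scatter) on the pyrimidin-2-yl compounds leaves fluoro and chloro not told apart in this assay and gives the halogen swap no readable effect here. With fluoro held constant, the group on the sulfur separates the compounds: pyrimidin-2-yl in place of 1-phenyl-1H-tetrazol-5-yl gives a number 17.6 percentage points higher from compound 2 to compound 4 (beyond the scatter) and in place of 5-methyl-1,3,4-thiadiazol-2-yl gives a number 18.5 percentage points higher from compound 1 to compound 4 (beyond the scatter) as modest steps, whereas the step between those two groups stayed within the scatter. Nothing available explains this difference between the groups on the sulfur.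

Open, as far as these compounds go, is whether fluoro and chloro also stay unseparated with 1-phenyl-1H-tetrazol-5-yl or 5-methyl-1,3,4-thiadiazol-2-yl on the sulfur. Also open, from the compounds shown here alone, is how a methoxy or a dimethylamino group would read at the aromatic position.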